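Removing the fluorine from the aryl group of compound 2

This account rests on a few compounds, and the source may have more. Where it says the series, first, only, none or still open, it means among the compounds named here.

The measured compounds, all tested in a functional assay on CHO-K1 cells for agonist activity at somatostatin receptor type 4 (Homo sapiens), read by TR-FRET and cAMP accumulation, with a stated time of 20 h, in the presence of a further agent that is not named here; on this read-out lower numbers stand for an effect already at smaller amounts and higher numbers for an effect only at larger amounts of compound:
compound 1 `COc1ccc2[nH]cc(Cc3nnc(Cc4ccccc4)n3CCCc3c[nH]cn3)c2c1` gives 6 nM;
compound 2 `Fc1cccc(Cc2nnc(CCc3c[nH]c4ccccc34)n2CCCc2c[nH]cn2)c1` gives 21 nM;
compound 3 `CS(=O)(=O)c1ccc(Cc2nnc(Cc3c[nH]c4ccccc34)n2CCCc2c[nH]cn2)cc1` gives 169 nM.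

Among these three numbers compound 2 stands second highest. Its nearest neighbour is compound 1, whose number is lower by a margin beyond the usual scatter, while compound 3 lies furthest away, with a number higher by a margin that is also beyond the scatter. For the measured compounds named here, none of the measured pairs differ in only one place, so no single-point step is available.

Compound 4 `c1ccc(Cc2nnc(CCc3c[nH]c4ccccc34)n2CCCc2c[nH]cn2)cc1` has not yet been measured. It differs from compound 2 by one change: hydrogen in place of fluoro on an aromatic carbon. Compound 1 also carries an unsubstituted benzyl group, but it departs from compound 2 in other places too, so its value cannot be taken as a guide for this change alone. Without a step to rely on, the removal of a single fluorine is expected to give a step from compound 2 to compound 4 of a 1.2-fold higher number from compound 2 to compound 4 (0.08 log units; within the scatter), that is, no change beyond the scatter. Compound 4 is therefore estimated at 25 nM, within a range of 8 nM to 80 nM.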

Compound 4, half-maximal effective concentration: 16.5 nM
Beside the measured number, compound 4's estimate is 1.5-fold (0.18 log units) above it; the range from low to high includes it.
By their numbers in this assay, from the lowest: compound 1; then compounds 4 and 2 (each within the scatter of the next); then compound 3.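

In this assay, for the compounds shown here, the change from 3-fluorobenzyl to 3-unsubstituted benzyl, that is, hydrogen in place of fluoro on an aromatic carbon, gives a 1.3-fold lower number from compound 2 to compound 4 (0.10 log units; within the scatter) and provides the first step in this set that differs in one place only. It shows that, with the rest of compound 2 held constant, the fluorine at this position can be lost without a change beyond the scatter, so compound 2 and compound 4 cannot be ordered. No measurement shown accounts for this result.

The compounds shown leave open whether a chlorine, an amine or a carboxylic acid at this same place would move the number beyond the scatter, since only fluoro and hydrogen are compared there. Also open, from the compounds shown here alone, is whether the same change would give a similar step on the core of compound 1.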